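From 3-methoxyphenyl to cyclohexyl on a weak compound

The source may report more compounds than this note shows. Statements on the series, on what has been measured and on what is new or still open speak of the compounds shown alone.

Measured so far in a functional assay on MCF7 cells (Homo sapiens) for antiproliferative activity, read by MTT assay, with a stated time of 72 h; a higher number here means a weaker inhibitor, a lower number a stronger inhibitor:
- compound 1 `COc1ncc(-c2ccc3c(c2)NC(=O)CO3)cc1NS(=O)(=O)c1ccc(F)cc1` gives 32300 nM
- compound 2 `COc1cccc(N2C(=O)COc3ccc(-c4cnc5ccccc5c4)cc32)c1` gives > 40000 nM

The result for compound 2 is a limit of the assay and not a number. Across the two compounds, the data record (the limit of > 40000 nM in this assay, at which 1 of the 2 values shown sits).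

Compound 3 `O=C1COc2ccc(-c3cnc4ccccc4c3)cc2N1C1CCCCC1` keeps the core of compound 2 and changes one group: cyclohexyl in place of 3-methoxyphenyl on an amide-type nitrogen in a ring. It has cyclohexyl in place of 3-methoxyphenyl on an amide-type nitrogen in a ring. Among the measured compounds shown here, no measured pair of compounds shows what this swap does. In this assay, the expectation is therefore no step beyond the usual scatter, in either direction. This rests on the limit for compound 2, > 40000 nM. The expected change is an at least 1.1-fold lower number from compound 2 to compound 3 (0.05 log units; that floor lies within the scatter). For compound 3 the estimated value is 35000 nM, with an expected range of 12000 nM to 80000 nM.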

Compound 3, half-maximal inhibitory concentration: > 40000 nM
Compound 3 ended at the assay's limit; the forecaster's own chance of this, stated with the estimate: 55%; middle value at least 1.1-fold (0.05 log units) from the limit.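

Compound 2 and compound 3 both end at a limit of the assay and not at a number, so no step can be read from this swap: the limit of > 40000 nM in this assay, at which 2 of the 3 values shown sit.

The compounds shown leave open whether cyclohexyl and 3-methoxyphenyl on this nitrogen differ at all in their effect on these cells.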